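Acyl chain variation: from compound 2 to compound 3

The compounds below may be only part of what the source reports. "The series", "measured", "known", "first", "only" and "open" are said of these compounds alone.

Measured in a functional assay on HeLa cells (Homo sapiens) for cytotoxicity, read by cell counting, with a stated time of 48 h; on this read-out higher numbers stand for an effect only at larger amounts of compound and lower numbers for an effect already at smaller amounts:
compound 1 `C=CCCCCCCCCC(=O)O[C@H]1[C@H](O)[C@H](n2ccc(N)nc2=O)O[C@@H]1CO` gives 0.05 ug/mL
compound 2 `CCCCCCCC/C=C\CCCCCCCC(=O)O[C@H]1[C@H](O)[C@H](n2ccc(N)nc2=O)O[C@@H]1CO` gives 0.06 ug/mL

Compound 2 has the highest of the two numbers; its nearest neighbour is compound 1, and the step of a 1.2-fold higher number from compound 1 to compound 2 (0.08 log units; within the scatter) lies within the scatter. Compound 3 `CCCCCCCCCCC(=O)O[C@H]1[C@H](O)[C@H](n2ccc(N)nc2=O)O[C@@H]1CO` is not yet measured; it differs from compound 2 by propyl in place of dec-1-en-1-yl on a saturated chain carbon, seven bonds along the chain from a carbonyl carbon. For the measured compounds named here, the only measured step, a 1.2-fold higher number from compound 1 to compound 2 (0.08 log units; within the scatter), also altered the acyl chain and stayed within the scatter, so no step beyond the scatter is expected in this assay: the expected step is a 1.2-fold lower number from compound 2 to compound 3 (0.08 log units; within the scatter). For compound 3 in this assay the estimate is 0.05 ug/mL, range 0.02 ug/mL to 0.12 ug/mL.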

Compound 3, concentration for half-maximal effect: 0.04 ug/mL
Estimate against measurement, compound 3: 1.3-fold (0.10 log units) above; the range from low to high includes it.
By their numbers in this assay, from the lowest: compounds 3, 1 and 2 (each within the scatter of the next).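

In this assay the acyl chain tolerates more than the earlier pair showed: with propyl in place of dec-1-en-1-yl there is a 1.5-fold lower number from compound 2 to compound 3 (0.18 log units; within the scatter), so these two groups read alike at this place. Ethyl in place of vinyl gives a 1.3-fold lower number from compound 1 to compound 3 (0.10 log units; within the scatter), so these two groups are not told apart either. No evidence is at hand on what lies behind these readings. Open, going by these compounds, is whether a much shorter chain, or an amine or a carboxylic acid on the chain, would stay within the scatter.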